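The compounds below may be only part of what the source reports. "The series", "measured", "known", "first", "only" and "open" are said of these compounds alone.

Compound 3 `CCNC(=O)c1noc(-c2cc(C(C)C)c(O)cc2O)c1-c1cc(CNC(C)=O)no1` belongs to a small set sharing one core. In a functional assay on HCT-116 cells (Homo sapiens) for inhibition (on this read-out higher numbers stand for weaker inhibition and lower numbers for stronger inhibition), compound 1 `CCNC(=O)c1noc(-c2cc(C(C)C)c(O)cc2O)c1-c1cc(CN)no1` gives 84 nM, compound 2 `CCNC(=O)c1noc(-c2cc(C(C)C)c(O)cc2O)c1-c1cc(CNC)no1` gives 164 nM, and compound 3 gives 167 nM. Compound 3 stands within the usual scatter of both neighbours: a 2.0-fold higher number from compound 1 to compound 3 (0.30 log units; within the scatter) and a 1.0-fold higher number from compound 2 to compound 3 (0.01 log units; within the scatter). The step to compound 4 `CCNC(=O)c1noc(-c2cc(C(C)C)c(O)cc2O)c1-c1cc(C(N)=O)no1` is carbamoyl in place of acetamidomethyl on an aromatic carbon. The earlier steps shown here, a 2.0-fold higher number from compound 1 to compound 2 (0.29 log units; within the scatter) and a 1.0-fold higher number from compound 2 to compound 3 (0.01 log units; within the scatter), all changed only what sits on the amine nitrogen and stayed within the scatter; none removed the acetamidomethyl group itself, so they bear on this step only loosely. A small step, if any, is therefore expected: a 1.1-fold lower number from compound 3 to compound 4 (0.05 log units; within the scatter). Compound 4 is estimated at 150 nM, between 60 nM and 400 nM.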

Compound 4, half-maximal inhibitory concentration: 79 nM
Estimate against measurement, compound 4: 1.9-fold (0.28 log units) above; measured number inside the range.
By their numbers in this assay, from the lowest: compounds 4, 1, 2 and 3 (each within the scatter of the next, the first and the last beyond it).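

For the compounds shown here, at this position, a 2.1-fold lower number from compound 3 to compound 4 (0.33 log units; beyond the scatter) and a 2.1-fold lower number from compound 2 to compound 4 (0.32 log units; beyond the scatter) are the only steps in this set beyond the scatter, and both are modest. Against the aminomethyl group there is no readable change, with a 1.1-fold lower number from compound 1 to compound 4 (0.03 log units; within the scatter) inside the scatter, so this side group needs no amine nitrogen to give a number in this range. From the compounds shown here alone, whether a carboxylic acid, a methyl ester or an ethyl amide at the same ring carbon would keep such a number stays open. Nothing available explains these differences.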